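Notes on aryl-piperazine variation in the oxazole series

This account rests on a few compounds, and the source may have more. Where it says the series, first, only, none or still open, it means among the compounds named here.

Measured so far:
- compound 1 `CCCc1nc(-c2ccccc2)c(CNCCCN2CCN(c3cccc(OC)c3)CC2)o1`: 36.4%
- compound 2 `CCCc1nc(-c2ccccc2)c(CNCCN2CCN(c3ccc(C)cc3)CC2)o1`: 48.1%
- compound 3 `CCCc1nc(-c2ccccc2)c(CNCCCN2CCN(c3ccc(C(F)(F)F)cc3)CC2)o1`: 51.6%

All three were run in an assay on HEK293 cells for inhibition of Voltage-dependent T-type calcium channel subunit alpha-1G (Homo sapiens), read by fluorescence, tested at 10 uM; a higher number here means more inhibition at the concentration tested (going by the name of the read-out), a lower number less inhibition. Compound 2 stands second highest of the three numbers; against compound 3 its value is within the scatter, while compound 1 lies lower by a margin beyond the scatter. Within the data shown here, the one step between compounds that differ in a single place is the aryl exchange a number 15.2 percentage points higher from compound 1 to compound 3 (beyond the scatter), a modest change.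

Compound 4 `CCCc1nc(-c2ccccc2)c(CNCCN2CCN(c3cccc(C)c3C)CC2)o1` is not yet measured. It differs from compound 2 by 2,3-dimethylphenyl in place of 4-methylphenyl on an amine nitrogen in a ring. Among the measured compounds shown here, the only measured step that bears on a change of this kind is the aryl exchange from compound 1 to compound 3, which was modest in size, and it concerns a different pair of aryl groups. From the compounds shown here alone, compound 2 itself has no single-place partner among the measured compounds, so its own sensitivity to the aryl group is unknown. On this basis the aryl change in compound 4 is expected to move this assay by little, with no clear direction, and a step within the scatter is the most likely outcome: the expected step is a number 2.1 percentage points lower from compound 2 to compound 4 (within the scatter). The estimate for compound 4 is therefore 46%, with a range from 30% to 62%.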

Compound 4, a percentage reported as inhibition, at one concentration (the size of the read-out at that concentration, not a potency): 66.7%
Estimate against measurement, compound 4: 20.7 percentage points below; measured number outside the range, above it.
By their numbers in this assay, from the lowest: compound 1; then compounds 2 and 3 (each within the scatter of the next); then compound 4.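

With the chain of compound 2 held fixed, the aryl group on the amine nitrogen in the ring is now shown to matter: a number 18.6 percentage points higher from compound 2 to compound 4 (beyond the scatter) in this assay. Among these compounds, compound 2 previously had no single-place partner, so this is the first reading of its sensitivity to this group, and the step is beyond the scatter. Both the leaving 4-methylphenyl and the entering 2,3-dimethylphenyl are aromatic rings of carbon only, with no hydrogen-bond donors or acceptors and no net charge, so the number moves without any change in those counts. No measurement available here explains the step.

The single step changes the substitution pattern and the number of methyl groups together, so the compounds shown cannot separate the two contributions, and it remains open whether 2,3-dimethylphenyl would give a similar step on the longer chain of compounds 1 and 3. Also open, from the compounds shown here alone, is how this position responds to a chlorophenyl group or a pyridine ring in place of the phenyl, and whether the read-out at a single concentration would carry over to a potency.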